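The source may report more compounds than this note shows. Statements on the series, on what has been measured and on what is new or still open speak of the compounds shown alone.

Measured compounds:
compound 1, `COCc1cccc(-c2ccc3ccc(C)nc3c2)c1`, which in a functional assay on CHO cells for inhibition of metabotropic glutamate receptor 5 (Rattus norvegicus), read by FLIPR and calcium flux (on this read-out higher numbers stand for weaker inhibition and lower numbers for stronger inhibition), gives 5800 nM
compound 2, `Cc1ccc2ccc(-c3cccc(OC(F)(F)F)c3)cc2n1`, which in this assay gives > 10000 nM

Compound 2 stands at the edge of the measured range: its value in this assay is a limit of the assay and not a number, so only that limit is known for it (the limit of > 10000 nM in this assay, at which 1 of the 2 values shown sits). Compound 3, `Cc1ccc2ccc(-c3cccc(C(F)(F)F)c3)cc2n1`, is the unmeasured partner of compound 2 and differs from it by trifluoromethyl in place of trifluoromethoxy on an aromatic carbon.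

Within the data shown here, only one measured step exists here, and it does not touch the same exchange: it runs an at least 1.7-fold higher number from compound 1 to compound 2 (0.23 log units; that floor lies within the scatter), where trifluoromethoxy replaced methoxymethyl. It offers no direct guide for swapping trifluoromethoxy for trifluoromethyl, and its own size is uncertain because one of its two values is a limit (the limit of > 10000 nM in this assay, at which 1 of the 2 values shown sits). Starting from a limit, compound 3 is expected to move little in this assay, a step that the limit leaves unreadable from compound 2 to compound 3, with no direction beyond the scatter. Compound 3 is therefore estimated at 12000 nM, within the range 3000 nM to 40000 nM, and a limit rather than a number is again quite likely.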

Compound 3, half-maximal inhibitory concentration: > 10000 nM
Compound 3: no number, only a limit (the forecaster's own chance of this, stated with the estimate: 60%); the middle value is on the limit's open side.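

In this assay compound 3 also gives only a limit of the assay, > 10000 nM. Trifluoromethyl on this aromatic carbon therefore joins trifluoromethoxy at the edge of the measured range, and the exchange between the two groups cannot be read, since both compounds sit at the same limit: the limit of > 10000 nM in this assay, at which 2 of the 3 values shown sit. The exchange of methoxymethyl for trifluoromethyl gives an at least 1.7-fold higher number from compound 1 to compound 3 (0.23 log units; that floor lies within the scatter), so this change, like the change to trifluoromethoxy, is known only as a floor and not as a size.

As far as these compounds go, compound 1 is the only one of the three with a number, so it stays open whether the true values of compound 2 and compound 3 lie close to it or far from it. Also open, from the compounds shown here alone, is how this position, meta to a large group, would answer to an amine, a carboxylic acid or a longer ether chain, and whether any such group would give stronger inhibition than compound 1 does.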